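The compounds below may be only part of what the source reports. "The series", "measured", "known", "first", "only" and "open" are said of these compounds alone.

For the measured compounds named here, compound 3 `CC(=O)O[C@@H]1[C@@H](OC(C)=O)[C@H](O)[C@@H](CO)O[C@H]1NC(=S)NNC(=O)Cn1cnc2ccccc21` holds the lowest of the two numbers known in a functional assay on PG cells (Homo sapiens) for cytotoxicity, read by MTT assay, with a stated time of 48 h; on this read-out lower numbers stand for an effect already at smaller amounts and higher numbers for an effect only at larger amounts of compound: in this assay compound 3 gives 82200 nM. Its nearest neighbour is compound 1 `CC(=O)O[C@@H]1[C@@H](OC(C)=O)[C@H](O)[C@@H](CO)O[C@H]1NC(=S)NNC(=O)Cn1cnc2c(N)ncnc21`, which in this assay gives 94500 nM; the two are separated by a 1.1-fold lower number from compound 1 to compound 3 (0.06 log units; within the scatter), a swap of the group on the saturated chain carbon bound to the carbonyl carbon. Compound 2 `CC(=O)O[C@@H]1[C@@H](OC(C)=O)[C@@H](O)[C@@H](CO)O[C@H]1NC(=S)NNC(=O)Cn1cnc2c(N)ncnc21` in this assay returns only a limit, > 100000 nM. The step onward to compound 4 `CC(=O)O[C@@H]1[C@@H](OC(C)=O)[C@@H](O)[C@@H](CO)O[C@H]1NC(=S)NNC(=O)Cn1cnc2ccccc21` is the two compounds have the same atoms and bonds and differ only in configuration as drawn: 1 of 5 stereo elements differ; a stereocentre at a saturated ring carbon is drawn R in compound 3 and S in compound 4. The same change is already on record between compounds 1 and 2, where it gave an at least 1.0-fold higher number from compound 1 to compound 2 (0.02 log units; that floor lies within the scatter); that floor is set by the limit of > 100000 nM in this assay, at which 1 of the 3 values shown sits, and the pairing rests on (the fact that compounds 1 and 2 differ only in the configuration as drawn). Going by the values given here, with the only comparable step bounded by a limit and lying at its floor within the scatter, compound 4 is expected to sit close to compound 3, with a real chance that this assay again reports only a limit rather than a number. The expected step is a 1.2-fold higher number from compound 3 to compound 4 (0.09 log units; within the scatter). Compound 4 is therefore estimated at 100000 nM, in a range from 60000 nM to 200000 nM.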

Compound 4, half-maximal effective concentration: > 100000 nM
Compound 4: only a limit was reported; the forecaster's own chance of this, stated with the estimate: 50%; the middle value sits exactly at the limit.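

The stereocentre at the saturated ring carbon has now been inverted with two different groups on the saturated chain carbon bound to the carbonyl carbon, and in this assay the second case gives an at least 1.2-fold higher number from compound 3 to compound 4 (0.08 log units; that floor lies within the scatter). So both compounds drawn S, compound 2 and compound 4, end in a limit of the assay, while both compounds drawn R return a number, and this holds for the group of 9 heavy atoms as well as for the group of 10 heavy atoms, with no compound shown going against it. The pattern still does not establish a real effect of the inversion, since the readable floor again lies within the scatter, and the step between the two compounds drawn S cannot be read, which leaves one point secure: the fact that compounds 3 and 4 differ only in the configuration as drawn.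

From the compounds shown here alone, it stays open how far beyond the limit compound 2 and compound 4 truly lie, and so whether the configuration at this carbon matters at all in this assay. Equally open, going by these compounds, is whether a carboxylic acid or an amine on the saturated chain carbon bound to the carbonyl carbon would move the number or keep the same pattern between the two configurations.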